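Aryl ether variation on the shared core

The source may hold more compounds than are shown below. What is called first, only, known or untested is meant among the compounds shown, and "the series" means these compounds.

In an assay on isolated protein for inhibition of Dihydrofolate reductase (Homo sapiens), read by spectrophotometry, using NADPH, with stated times of 5 s and 6 min (on this read-out lower numbers stand for stronger inhibition and higher numbers for weaker inhibition), compound 3 `COc1ccc(OCCCON2C(N)=NC(N)=NC23CCOCC3)cc1` gives 11.1 nM. Within the data shown here, compound 3 stands second highest of the three numbers so far: compound 2 `NC1=NC2(CCOCC2)N(OCCCOc2ccc(Cl)cc2Cl)C(N)=N1` gives 7.46 nM, and a 1.5-fold higher number from compound 2 to compound 3 (0.17 log units; within the scatter) is within the scatter; compound 1 `NC1=NC2(CCOCC2)N(OCCCOc2ccc(F)cc2)C(N)=N1` gives 46.6 nM, and a 4.2-fold lower number from compound 1 to compound 3 (0.62 log units; beyond the scatter) lies beyond the scatter. Compound 4 `CC(C)(C)c1ccc(OCCCON2C(N)=NC(N)=NC23CCOCC3)cc1` is not yet measured and differs from compound 3 in one place.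
tert-butyl in place of methoxy on an aromatic carbon
The step that bears most directly on this change is a 4.2-fold lower number from compound 1 to compound 3 (0.62 log units; beyond the scatter), which exchanged one substituent on the same aromatic carbon. a 6.2-fold lower number from compound 1 to compound 2 (0.80 log units; beyond the scatter) altered a different substitution pattern. Among the measured compounds shown here, no measured step involves tert-butyl, so the direction is open, and a step near the scatter is expected in this assay. For compound 4 the estimate is 12 nM, range 4 nM to 35 nM, meaning a 1.1-fold higher number from compound 3 to compound 4 (0.03 log units; within the scatter).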

Compound 4, half-maximal inhibitory concentration: 3.72 nM
Estimate against measurement, compound 4: 3.2-fold (0.51 log units) above; measured number below the stated range.
By their numbers in this assay, from the lowest: compounds 4, 2 and 3 (each within the scatter of the next, the first and the last beyond it); then compound 1.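

At this aromatic carbon, tert-butyl gives a lower number than methoxy (a 3.0-fold lower number from compound 3 to compound 4 (0.47 log units; beyond the scatter)) in this assay, so the oxygen of methoxy and its hydrogen-bond acceptor are not required for a low number here. The step from fluoro is larger (a 13-fold lower number from compound 1 to compound 4 (1.10 log units; beyond the scatter)), and across compounds 1, 3 and 4 the number falls from fluoro to methoxy to tert-butyl, each step beyond the scatter. Nothing available explains why tert-butyl gives the lowest of these three numbers.

On these data alone, whether the number keeps falling with a phenyl ring or a cyclohexyl ring on this carbon remains open. So does the outcome with an amine or a carboxylic acid there.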